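The source may report more compounds than this note shows. Statements on the series, on what has been measured and on what is new or still open speak of the compounds shown alone.

Compound 1 `NC(=O)c1sc(-c2ccc(Cl)cc2)nc1C(Br)Br` is the primary amide of this small series. In an ADME assay on BHK15 cells (Mesocricetus auratus) for inhibition, read by XTT assay, with a stated time of 36 h (on this read-out lower numbers stand for stronger inhibition of growth and higher numbers for weaker inhibition of growth), compound 1 gives 99700 nM, which places it second highest of the three numbers measured. Compound 2 `CCNC(=O)c1sc(-c2ccc(Cl)cc2)nc1C(Br)Br` carries an ethyl group on the amide nitrogen and gives 33300 nM in this assay; compound 3 `CC(C)OC(=O)c1sc(-c2ccc(Cl)cc2)nc1C(Br)Br` is the isopropyl ester and gives 372000 nM. The step shows a 3.0-fold lower number from compound 1 to compound 2 (0.48 log units; beyond the scatter), whereas the step shows a 3.7-fold higher number from compound 1 to compound 3 (0.57 log units; beyond the scatter) and the step shows an 11-fold higher number from compound 2 to compound 3 (1.05 log units; beyond the scatter).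

Compound 4 `CSC(=O)c1sc(-c2ccc(Cl)cc2)nc1C(Br)Br` differs from compound 1 in one place: methylsulfanyl in place of amino on a carbonyl carbon. Like the change to compound 3, this removes the hydrogen-bond donor of the amide, so the step from compound 1 to compound 3 is the closest guide. Compound 4 is therefore expected to give a higher number than compound 1, with a step of about a 2.0-fold higher number from compound 1 to compound 4 (0.30 log units; within the scatter), because the step of a 3.7-fold higher number from compound 1 to compound 3 (0.57 log units; beyond the scatter) moved the same way. The estimate for compound 4 in this assay is 200000 nM, within a range from 70000 nM to 600000 nM.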

Compound 4, concentration for 50% growth inhibition: 369000 nM
Compound 4: the middle estimate sits 1.8-fold (0.27 log units) below what was measured; low and high end bracket the measured number.
By their numbers in this assay, from the lowest: compound 2; then compound 1; then compounds 4 and 3 (each within the scatter of the next).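

Putting methylsulfanyl in place of amino on the carbonyl carbon gives a 3.7-fold higher number from compound 1 to compound 4 (0.57 log units; beyond the scatter) in this assay, and the swap between the two non-nitrogen groups gives a 1.0-fold lower number from compound 3 to compound 4 (0.00 log units; within the scatter), so methylsulfanyl and isopropoxy cannot be told apart here. Among these four compounds, the two with nitrogen on the carbonyl carbon therefore give lower numbers than the two without, with the widest gap at an 11-fold higher number from compound 2 to compound 4 (1.04 log units; beyond the scatter). Nothing measured here explains these differences.

From the compounds shown here alone, it remains open whether the lower numbers depend on a hydrogen on that nitrogen, which a dimethylamino group on the carbonyl carbon could help to separate. A longer chain on the nitrogen, such as butylamino, would show whether the trend seen with ethylamino continues.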